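A chloro-for-trifluoromethyl swap on the amide side of the series

The source may hold more compounds than are shown below. What is called first, only, known or untested is meant among the compounds shown, and "the series" means these compounds.

Of the compounds shown here, three sharing one core have been measured in a functional assay on SK-MEL-28 cells (Homo sapiens) for cytotoxicity, read by MTT assay; a lower number here means a stronger inhibitor, a higher number a weaker inhibitor. Compound 1 `O=S(=O)(NCCNc1nccc(-c2c(-c3cccc(F)c3)nc3sccn23)n1)c1ccc(Cl)cc1` gives 18600 nM. Compound 2 `O=S(=O)(NCCNc1nccc(-c2c(-c3cccc(F)c3)nc3sccn23)n1)c1ccc(C(F)(F)F)cc1` gives 8450 nM. Compound 3 `O=C(NCCNc1nccc(-c2c(-c3cccc(F)c3)nc3sccn23)n1)c1ccc(C(F)(F)F)cc1` gives 9260 nM. Between compound 2 and compound 1 the change is chloro in place of trifluoromethyl on an aromatic carbon and the step is a 2.2-fold higher number from compound 2 to compound 1 (0.34 log units; beyond the scatter). Between compound 1 and compound 3 the step is a 2.0-fold lower number from compound 1 to compound 3 (0.30 log units; within the scatter). The difference between the cores of compound 2 and compound 3 is not broken down here; their values sit close together in this assay.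

Compound 4 `O=C(NCCNc1nccc(-c2c(-c3cccc(F)c3)nc3sccn23)n1)c1ccc(Cl)cc1` has not yet been measured. It differs from compound 3 by chloro in place of trifluoromethyl on an aromatic carbon, the same change that was made from compound 2 to compound 1, at the same kind of place. On that precedent, the step from compound 3 to compound 4 is expected to be a 1.9-fold higher number from compound 3 to compound 4 (0.29 log units; within the scatter), resting on the step of a 2.2-fold higher number from compound 2 to compound 1 (0.34 log units; beyond the scatter). Compound 4 is therefore estimated at 18000 nM, with a likely range from 7000 nM to 45000 nM.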

Compound 4, half-maximal inhibitory concentration: 8160 nM
The estimate for compound 4 lay 2.2-fold (0.34 log units) above the measured number, within the range that was stated.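

Chloro in place of trifluoromethyl on the carbonyl side gave a 1.1-fold lower number from compound 3 to compound 4 (0.05 log units; within the scatter) in this assay, so the two compounds cannot be told apart there, while with the chloro kept, (4-chlorophenyl)carbonyl in place of (4-chlorophenyl)sulfonyl gave a 2.3-fold lower number from compound 1 to compound 4 (0.36 log units; beyond the scatter), a modest step. Set beside the earlier step on the sulfonyl side, the swap gives no firm sign that its outcome depends on the core: the same change on two cores in this assay, a 2.2-fold higher number (0.34 log units; beyond the scatter) from compound 2 to compound 1 and a 1.1-fold lower number (0.05 log units; within the scatter) from compound 3 to compound 4, 2.5-fold (0.40 log units) apart, within the scatter of two such steps. This does not show that the change carries over with a fixed size, since two pairs in a single assay, one step just beyond the scatter and the other within it, can neither establish nor exclude a modest dependence on the core.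

The compounds shown leave open how a methoxy group, a nitrile or an amine would compare with chloro and trifluoromethyl on that aromatic carbon on either core. They also leave open whether a longer chain in the linker would alter the comparison between the carbonyl and sulfonyl compounds.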